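The compounds below may be only part of what the source reports. "The series", "measured", "known", "first", "only" and "open" are said of these compounds alone.

Working notes on the series. For the measured compounds named here, in a functional assay on HEK293 cells for agonist activity at Bombesin receptor subtype-3 (Mus musculus), read by luminescence and calcium flux, with a stated time of 10 min (on this read-out lower numbers stand for an effect already at smaller amounts and higher numbers for an effect only at larger amounts of compound), compound 1 `CCC(C)(C)Cc1c[nH]c(CCc2ccc(-c3cnccn3)cc2)n1` gives 11 nM, the second highest of the three numbers measured so far. Compound 3 `c1ccc(-c2ccc(CCc3nc(CC4CCCC4)c[nH]3)cc2)nc1` gives 22 nM, which lies within the scatter of compound 1, so no order between these two is claimed. Going by the values given here, compound 2 `CCC(C)(C)Cc1c[nH]c(CCc2ccc(-c3cccc(N)n3)cc2)n1` gives 3.9 nM, and the step of a 2.8-fold lower number from compound 1 to compound 2 (0.45 log units; beyond the scatter) is the only step among the measured pairs that goes beyond the scatter; it is a modest one.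

Compound 4 `CCC(C)(C)Cc1c[nH]c(CCc2ccc(-c3cccnc3)cc2)n1` has not yet been measured. It differs from compound 1 in one place: pyridin-3-yl in place of pyrazin-2-yl on an aromatic carbon. Among the compounds with values here, no measured step covers this exchange directly. Within the data shown here, the only step at the same aromatic carbon, a 2.8-fold lower number from compound 1 to compound 2 (0.45 log units; beyond the scatter), puts 6-aminopyridin-2-yl in place of pyrazin-2-yl and lowers the number modestly, but the present change enters pyridin-3-yl instead, and nothing measured shows how this assay answers to that group. The expectation is therefore a step of no clear direction, most likely within the scatter. For compound 4 the estimate is 15 nM, with a range from 5 nM to 45 nM. The estimated step of a 1.4-fold higher number from compound 1 to compound 4 (0.13 log units; within the scatter) is expected to stay inside the usual scatter.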

Compound 4, half-maximal effective concentration: 4.3 nM
Beside the measured number, compound 4's estimate is 3.5-fold (0.54 log units) above it; measured number outside the range, below it.
By their numbers in this assay, from the lowest: compounds 2 and 4 (each within the scatter of the next); then compounds 1 and 3 (each within the scatter of the next).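

At this aromatic carbon, para to a large group, a 2.6-fold lower number from compound 1 to compound 4 (0.41 log units; beyond the scatter) in this assay, so pyrazin-2-yl is now left behind beyond the scatter by two different groups rather than by 6-aminopyridin-2-yl alone. With a 1.1-fold higher number from compound 2 to compound 4 (0.04 log units; within the scatter), the two exchanges cannot be told apart here, and the amino group of compound 2 is not needed to reach this level, since compound 4 carries no hydrogen-bond donor in the entering group and, with its one hetero atom in the ring, stands within the scatter of compound 2. No measurement at hand explains why the ring with 1 hetero atom gives a lower number than the ring with 2 hetero atoms.

The compounds shown cover only three aromatic rings at this carbon, so it remains open whether the lower number depends on a ring nitrogen at all, which a plain phenyl ring in the same place would address. On these data alone, it also remains open how this position answers to a group of another kind, such as a carboxylic acid or an aminomethyl group on the pyridin-3-yl ring.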